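Trifluorophenyl swap in a series held at the limit

This account rests on a few compounds, and the source may have more. Where it says the series, first, only, none or still open, it means among the compounds named here.

The three measured compounds share one core and differ only in the aryl group on a saturated chain carbon bound to a nitrogen on an aromatic ring. In a functional assay on HOS cells (Homo sapiens) for antiproliferative activity, with a stated time of 72 h (on this read-out lower numbers stand for stronger inhibition and higher numbers for weaker inhibition), compound 1 (`OC[C@H]1O[C@@H](n2cnc3c(NCc4ccc(Br)cc4)ncnc32)[C@H](O)[C@@H]1O`) gives > 166000 nM, which is a limit and not a number. Compound 2 (`OC[C@H]1O[C@@H](n2cnc3c(NCc4ccc(Cl)cc4Cl)ncnc32)[C@H](O)[C@@H]1O`) gives > 166000 nM, also a limit. Compound 3 (`OC[C@H]1O[C@@H](n2cnc3c(NCc4ccc(Cl)c(Cl)c4)ncnc32)[C@H](O)[C@@H]1O`) gives > 166000 nM, likewise a limit.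

Compound 3 thus has no numerical position in the series, and the whole set stands at the limit of > 166000 nM in this assay, at which 3 of the 3 values shown sit.

The next change leads to compound 4 (`OC[C@H]1O[C@@H](n2cnc3c(NCc4ccc(F)c(F)c4F)ncnc32)[C@H](O)[C@@H]1O`), with 2,3,4-trifluorophenyl in place of 3,4-dichlorophenyl on a saturated chain carbon bound to a nitrogen on an aromatic ring.

Three measured steps swap the same aryl group: a step that the two limits leave unreadable from compound 1 to compound 2, a step that the two limits leave unreadable from compound 1 to compound 3 and a step that the two limits leave unreadable from compound 2 to compound 3. None gives a size to carry forward, so no direction can be drawn from them. All that can be drawn is that three aryl variants left this assay at its limit, and the same outcome is the likeliest one here.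

The expected result is a step that the limit leaves unreadable from compound 3 to compound 4, with no readable change foreseen. For compound 4 the estimated value is 170000 nM, with an expected range from 60000 nM to 350000 nM.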

Compound 4, half-maximal inhibitory concentration: > 166000 nM
Compound 4 gave a limit, no number (the forecaster's own chance of this, stated with the estimate: 80%); the middle value does not contradict the limit.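

No new step can be read: compound 4 gives a limit in this assay, as do compound 1, compound 2 and compound 3, so its steps from those three have no size. The series stands thus: the limit of > 166000 nM in this assay, at which 4 of the 4 values shown sit.

The compounds shown leave open whether any aryl group at this place gives a numerical value, and how these four aryl variants rank.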